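A few compounds are considered here, and "the series" means these few. Any claim that something is new, unique, unknown or untested is made for them only; others in the source may bear on it.

Among the three compounds so far measured in an ADME assay on a cell-free system (plasma, Homo sapiens) (on this read-out lower numbers stand for a smaller free fraction and higher numbers for a larger free fraction), compound 3, `O=C(O)COc1ccc(Cl)cc1C#Cc1cccnc1`, stands highest with 0.029. Compound 1, `COCCN(C)S(=O)(=O)c1ccc(C)c(C#Cc2cc(Cl)ccc2OCC(=O)O)c1`, gives 0.006 in this assay, and compound 2, `Cc1ccc(S(=O)(=O)NC(C)C)cc1C#Cc1cc(Cl)ccc1OCC(=O)O`, gives 0.004. For the measured compounds named here, the only single-point step measured, a 1.5-fold lower number from compound 1 to compound 2 (0.18 log units; within the scatter), concerns the amine attached to the sulfonyl sulfur and says nothing about introducing such a group onto a ring that lacks one.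

Compound 4, `CN(C)S(=O)(=O)c1cncc(C#Cc2cc(Cl)ccc2OCC(=O)O)c1`, differs from compound 3 in one place: dimethylsulfamoyl in place of hydrogen on an aromatic carbon. Going by the values given here, no measured step bears directly on this change. What the data do show is that compound 1 and compound 2, which each carry a related sulfamoyl group but differ from compound 3 in more than one place, both give lower numbers than compound 3 in this assay. Among the compounds with values here, on that indirect basis compound 4 is expected to give a lower number than compound 3, a step of a 1.9-fold lower number from compound 3 to compound 4 (0.29 log units; within the scatter), with wide uncertainty since the comparison rests on no single-point step. The estimate for compound 4 in this assay is 0.015, with a range from 0.006 to 0.035.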

Compound 4, unbound fraction: 0.033
Compound 4: middle estimate off by 2.2-fold (0.34 log units), on the low side; measured number inside the range.
By their numbers in this assay, from the lowest: compounds 2 and 1 (each within the scatter of the next); then compounds 3 and 4 (each within the scatter of the next).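

Dimethylsulfamoyl in place of hydrogen on an aromatic carbon, two atoms from the ring nitrogen and meta to a large group, comes with a 1.1-fold higher number from compound 3 to compound 4 (0.06 log units; within the scatter) in this assay. At this position, then, a group of this size with no net charge can enter the six-membered aromatic ring with 1 nitrogen without a change in the unbound fraction beyond the scatter, whereas the earlier single step concerned only the amine on the sulfonyl sulfur. Nothing measured here accounts for this result.

The compounds shown leave open whether an isopropylamino or (2-methoxyethyl)(methyl)amino group on the sulfonyl sulfur would behave the same way on this core, and what a nitrile, a primary amine or a carboxylic acid would do at this position. For the compounds shown here, no single-place pair links compound 1 or compound 2 to compound 3 or compound 4, so what separates their numbers stays unassigned between the ring nitrogen, the methyl group and any other difference in the core.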